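Replacing benzyl with 3,4-dinitrophenyl on compound 3

The source may hold more compounds than are shown below. What is called first, only, known or untested is meant among the compounds shown, and "the series" means these compounds.

Measured in a functional assay on RS4-11 cells (Homo sapiens) for inhibition, read by CCK-8 assay, with a stated time of 48 h; a lower number here means a stronger inhibitor, a higher number a weaker inhibitor:
- Compound 1 `O=S(=O)(NCCNC(=S)Nc1cccc(Cl)c1)c1ccc(-c2ccccc2OCc2ccccc2)s1`: > 50000 nM (a limit)
- Compound 2 `O=C(NCCNS(=O)(=O)c1ccc(-c2ccccc2Oc2ccc([N+](=O)[O-])c([N+](=O)[O-])c2)s1)Nc1cc(Cl)cc(Cl)c1`: 2100 nM
- Compound 3 `COc1cccc(NC(=O)NCCNS(=O)(=O)c2ccc(-c3ccccc3OCc3ccccc3)s2)c1`: > 20000 nM (a limit)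

In this assay, compound 3 reads > 20000 nM, which is a limit and not a number. Compound 4 `COc1cccc(NC(=O)NCCNS(=O)(=O)c2ccc(-c3ccccc3Oc3ccc([N+](=O)[O-])c([N+](=O)[O-])c3)s2)c1` differs from it by one change: 3,4-dinitrophenyl in place of benzyl on an oxygen on an aromatic ring. In words, this is 3,4-dinitrophenyl in place of benzyl on an oxygen on an aromatic ring.

For the measured compounds named here, the one measured step, a step that the two limits leave unreadable from compound 1 to compound 3, cannot be sized and concerns a group on an amine nitrogen, so it does not bear on this change. Going by the values given here, no measured step isolates the swap. Among the compounds with values here, compound 2 carries the 3,4-dinitrophenyl, reads 2100 nM, and is the only compound here with a number. It also differs from compound 4 in the group at the other end, so it offers only a loose guide.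

On that value of compound 2, 2100 nM, the expected result is a strengthening beyond the scatter, an at least 5.0-fold lower number from compound 3 to compound 4 (0.69 log units; beyond the scatter). Compound 4 is estimated at 4000 nM, with an expected range from 1200 nM to 15000 nM.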

Compound 4, half-maximal inhibitory concentration: 1300 nM
Estimate against measurement, compound 4: 3.1-fold (0.49 log units) above, within the range that was stated.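

In this assay, for the compounds shown here, the change on the oxygen on an aromatic ring can now be sized for the first time: with the 3-methoxyphenyl group kept, 3,4-dinitrophenyl in place of benzyl gives an at least 15-fold lower number from compound 3 to compound 4 (1.18 log units; beyond the scatter) in one change. That size is only a lower bound, because compound 3 stands at a limit: the limit of > 20000 nM in this assay, at which 1 of the 4 values shown sits. With 3,4-dinitrophenyl kept on the oxygen, the swap on the amide-type nitrogen gives a 1.6-fold lower number from compound 2 to compound 4 (0.21 log units; within the scatter), so 3-methoxyphenyl and 3,5-dichlorophenyl are not told apart in this setting.

Left open is whether a phenyl ring carrying a single nitro group, an amine or a carboxylic acid would serve on that oxygen in place of 3,4-dinitrophenyl. Also open, as far as these compounds go, is whether plain phenyl there would give a number and not a limit.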